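This account rests on a few compounds, and the source may have more. Where it says the series, first, only, none or still open, it means among the compounds named here.

In a functional assay on HCT-116 cells (Homo sapiens) for inhibition, read by sulforhodamine B assay, with a stated time of 3 days (on this read-out lower numbers stand for stronger inhibition of growth and higher numbers for weaker inhibition of growth), the measured compounds are:
compound 1 `Cc1ccc(COc2ccc(C(=O)/C=C/c3ccc(Cl)cc3)cc2)cc1`: > 50000 nM, which is a limit of the assay rather than a number
compound 2 `O=C(/C=C/c1ccccc1Cl)c1ccc(OCc2ccccc2)cc1`: 14900 nM
compound 3 `COc1ccc(/C=C/C(=O)c2ccc(OCc3ccccc3)cc2)cc1`: 36900 nM

Among the two plain numbers, compound 3 gives the higher one, the step being a 2.5-fold higher number from compound 2 to compound 3 (0.39 log units; beyond the scatter). Compound 4 `O=C(/C=C/c1ccc(Cl)cc1)c1ccc(OCc2ccccc2)cc1` differs from compound 3 by chloro in place of methoxy on an aromatic carbon. No measured step swaps these exact groups; the one step shown, a 2.5-fold higher number from compound 2 to compound 3 (0.39 log units; beyond the scatter), replaced a 2-chlorophenyl with the 4-methoxyphenyl and raised the number modestly. Returning to a chloro, here para to a large group, is therefore expected to lower the number somewhat, though compound 1, which also carries 4-chlorophenyl, shows only (the limit of > 50000 nM in this assay, at which 1 of the 3 values shown sits). Compound 4 is expected at 20000 nM, within 7000 nM to 60000 nM. The expected step is a 1.8-fold lower number from compound 3 to compound 4 (0.27 log units; within the scatter).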

Compound 4, concentration for 50% growth inhibition: > 50000 nM
Compound 4: no number, only a limit; the forecaster's own chance of this, stated with the estimate: 30%; middle value at least 2.5-fold (0.39 log units) from the limit.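

Putting chloro in place of methoxy at this place does not restore growth inhibition in this assay: the change gives an at least 1.3-fold higher number from compound 3 to compound 4 (0.13 log units; that floor lies within the scatter), so these two groups cannot be ranked here. Where the chlorine sits does count, with 4-chlorophenyl in place of 2-chlorophenyl giving an at least 3.3-fold higher number from compound 2 to compound 4 (0.52 log units; beyond the scatter). Compound 1 and compound 4 each give only a limit, so the step between them cannot be read: the limit of > 50000 nM in this assay, at which 2 of the 4 values shown sit.

As far as these compounds go, how an amine or a hydroxyl group on this same aromatic carbon would read stays open, and so does 3-chlorophenyl as a further placing of the chlorine.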